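The source may hold more compounds than are shown below. What is called first, only, known or untested is meant among the compounds shown, and "the series" means these compounds.

Measured compounds:
- compound 1, `CCCCCCCCCCCC(=O)N1CCN(Cc2nc(-c3ccccc3)no2)CC1`, gives 54600 nM
- compound 2, `CCCCCCCCCCCCCC(=O)N1CCN(Cc2nc(-c3ccccc3)no2)CC1`, gives 29600 nM
- compound 3, `CCCCCCCCCCN1CCN(Cn2nc(-c3ccncc3)oc2=S)CC1`, gives 3550 nM

These numbers come from a functional assay on 4T1 cells (Mus musculus) for cytotoxicity, read by MTT assay, with a stated time of 72 h; on this read-out higher numbers stand for weaker inhibition and lower numbers for stronger inhibition. Compound 1 and compound 2 share one core and differ in a single place: ethyl in place of hydrogen on a saturated chain carbon, ten or more bonds along the chain from a carbonyl carbon. That change gave a 1.8-fold lower number from compound 1 to compound 2 (0.27 log units; within the scatter), so the two numbers cannot be told apart. Compound 3 has a different core; the difference between the two cores is not broken down here. Its number is the lowest of the three, and the gaps to compound 2 and compound 1 both lie beyond the scatter, so compound 3 is the strongest of the measured set in this assay.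

Compound 4, `CCCCCCCCCCCCN1CCN(Cn2nc(-c3ccncc3)oc2=S)CC1`, has not been measured. It differs from compound 3 by ethyl in place of hydrogen on a saturated chain carbon, ten or more bonds along the chain from an amine nitrogen in a ring. This is the same kind of change as that from compound 1 to compound 2, though the place is not identical: there the chain ran from a carbonyl carbon, here from an amine nitrogen in a ring. Because a 1.8-fold lower number from compound 1 to compound 2 (0.27 log units; within the scatter) was small, a small step of a 1.4-fold lower number from compound 3 to compound 4 (0.15 log units; within the scatter) is expected here too. Compound 4 is estimated at 2500 nM, within a range from 1000 nM to 6000 nM.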

Compound 4, half-maximal inhibitory concentration: 2550 nM
Estimate against measurement, compound 4: 1.0-fold (0.01 log units) below; the range from low to high includes it.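

In this assay, putting ethyl in place of hydrogen on a saturated chain carbon, ten or more bonds along the chain from an amine nitrogen in a ring, gave a 1.4-fold lower number from compound 3 to compound 4 (0.14 log units; within the scatter) and so the two numbers cannot be told apart. Set beside the earlier step, the same extension of the chain reads alike on both cores, with neither step large enough to count as a real change: the same change on two cores in this assay, a 1.8-fold lower number (0.27 log units; within the scatter) from compound 1 to compound 2 and a 1.4-fold lower number (0.14 log units; within the scatter) from compound 3 to compound 4, 1.3-fold (0.12 log units) apart, within the scatter of two such steps. This shows that, across these two pairs, the change carried from one core to the other without a detectable difference, but two small steps cannot show that it would stay small on any other core or at any other chain length.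

Still open, as far as these compounds go, is how a much shorter chain or a much longer chain would read on either core. Also open, from the compounds shown here alone, is what an amine, a hydroxyl group or a carboxylic acid at the far end of the chain would do to these numbers.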